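The source may report more compounds than this note shows. Statements on the series, on what has been measured and on what is new or still open speak of the compounds shown alone.

Measured in a functional assay on PC-3 cells (Homo sapiens) for cytotoxicity, read by colorimetric assay; a lower number here means a stronger inhibitor, a higher number a weaker inhibitor:
- compound 1 `O=C(NO)c1ccc(CN2C(=O)/C(=C3\Nc4ccccc4\C3=N/O)c3cc(F)ccc32)cc1` gives 50 nM
- compound 2 `COc1ccc2c(c1)/C(=C1/Nc3ccccc3/C1=N\O)C(=O)N2Cc1ccc(/C=C/C(=O)NO)cc1` gives 30 nM
- compound 3 `Cc1ccc2c(c1)/C(=C1/Nc3ccccc3/C1=N\O)C(=O)N2Cc1ccc(C(=O)NO)cc1` gives 90 nM

Compound 3 and compound 1 lie within the scatter of each other. Compound 2 has a lower number than compound 3, and that gap goes beyond the scatter.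

The next change leads from compound 3 to compound 4 `COc1ccc2c(c1)/C(=C1/Nc3ccccc3/C1=N\O)C(=O)N2Cc1ccc(C(=O)NO)cc1`, with methoxy in place of methyl on an aromatic carbon. For the measured compounds named here, the one measured step at this carbon is a 1.8-fold higher number from compound 1 to compound 3 (0.26 log units; within the scatter), methyl in place of fluoro, and it stays within the scatter. Going by the values given here, compound 4 shares the methoxy with compound 2, which differs elsewhere in the structure and gives 30 nM, so no measured step isolates the methoxy.

The expected step in this assay therefore stays within the scatter, with at most a slight move to a lower number, estimated as a 1.5-fold lower number from compound 3 to compound 4 (0.18 log units; within the scatter). For compound 4 the estimated value is 60 nM, with an expected range from 25 nM to 140 nM.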

Compound 4, half-maximal inhibitory concentration: 30 nM
The estimate for compound 4 lay 2.0-fold (0.30 log units) above the measured number; measured number inside the range.
By their numbers in this assay, from the lowest: compounds 2, 4, 1 and 3 (each within the scatter of the next, the first and the last beyond it).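

In this assay, for the compounds shown here, methoxy in place of methyl on this aromatic carbon gives a 3.0-fold lower number from compound 3 to compound 4 (0.48 log units; beyond the scatter) as the only step at this carbon that goes beyond the scatter. Methoxy in place of fluoro gives a 1.7-fold lower number from compound 1 to compound 4 (0.22 log units; within the scatter) and stays within the scatter, so at this carbon only the methyl and methoxy pair is separated. With methoxy held on this carbon, hydroxycarbamoyl in place of 2-(hydroxycarbamoyl)ethenyl gives no change at the digits printed from compound 2 to compound 4 (within the scatter) and no difference can be read from that change.

Still open, as far as these compounds go, is whether an amine or a carboxylic acid on this aromatic carbon would match methoxy, and whether the methyl to methoxy step recurs with the 2-(hydroxycarbamoyl)ethenyl chain. No available evidence bears on what lies behind the methoxy step.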